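Moving a methyl around the piperidine ring

A few compounds are considered here, and "the series" means these few. Any claim that something is new, unique, unknown or untested is made for them only; others in the source may bear on it.

Compound 3 `COc1cc2c(Nc3nc4ccc(C(=O)Nc5c(C)cc(C)cc5C)cc4s3)ncnc2cc1OCCCN1CCCCC1C` gives 8800 nM in a functional assay on NCI-H661 cells (Homo sapiens) for cytotoxicity, read by WST assay, with a stated time of 72 h (on this read-out lower numbers stand for stronger inhibition and higher numbers for weaker inhibition), the second highest of three numbers. Compound 1 `COc1cc2c(Nc3nc4ccc(C(=O)Nc5c(C)cccc5Cl)cc4s3)ncnc2cc1OCCCN1CCC(C)CC1` gives 7900 nM, within the scatter of compound 3. Compound 2 `COc1cc2c(Nc3nc4ccc(C(=O)Nc5c(C)cccc5C)cc4s3)ncnc2cc1OCCCN1CCC(C)CC1` gives 72300 nM, well apart from both. Compound 4 `COc1cc2c(Nc3nc4ccc(C(=O)Nc5c(C)cc(C)cc5C)cc4s3)ncnc2cc1OCCCN1CCC(C)CC1` is not yet measured; it differs from compound 3 by 4-methylpiperidin-1-yl in place of 2-methylpiperidin-1-yl on a saturated chain carbon, three bonds along the chain from an oxygen on an aromatic ring. Among the measured compounds shown here, the only measured single-point step, a 9.2-fold higher number from compound 1 to compound 2 (0.96 log units; beyond the scatter), concerns a change on an aromatic carbon and does not bear on a shift of a methyl within the piperidine ring, so no step beyond the scatter is expected, giving an estimated no change at the digits printed from compound 3 to compound 4 (within the scatter). Compound 4 is therefore expected to give about 8800 nM, with a range from 3500 nM to 22000 nM.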

Compound 4, half-maximal inhibitory concentration: 7700 nM
Compound 4: middle estimate off by 1.1-fold (0.06 log units), on the high side; measured number inside the range.
By their numbers in this assay, from the lowest: compounds 4, 1 and 3 (each within the scatter of the next); then compound 2.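

In this assay, moving the methyl from 2-methylpiperidin-1-yl to 4-methylpiperidin-1-yl gives a 1.1-fold lower number from compound 3 to compound 4 (0.06 log units; within the scatter), so this shift within the ring leaves the number unchanged within the scatter. At the other end of the molecule, adding a further methyl gives a 9.4-fold lower number from compound 2 to compound 4 (0.97 log units; beyond the scatter), whereas 2,4,6-trimethylphenyl in place of 2-chloro-6-methylphenyl gives a 1.0-fold lower number from compound 1 to compound 4 (0.01 log units; within the scatter). Nothing available explains these results. Still open, going by these compounds, is how an unsubstituted piperidine, a morpholine or a longer chain in place of the propyl link would read in this assay.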